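The compounds below may be only part of what the source reports. "The series", "measured", "known", "first", "only" and "open" are said of these compounds alone.

Measured so far in a functional assay on COLO 205 cells (Homo sapiens) for cytotoxicity, read by MTT assay, with a stated time of 24 h; on this read-out higher numbers stand for weaker inhibition and lower numbers for stronger inhibition:
- compound 1, `CCCCCCCCCCn1cc(-c2nc3ccccc3cc2CC)nn1`: a limit only, > 100 ug/mL
- compound 2, `CCCCCCCCCCn1cc(-c2nc3ccccc3cc2CCC)nn1`: a limit only, > 100 ug/mL
- compound 3, `CCCCCc1cc2ccccc2nc1-c1cn(-c2ccc(F)cc2)nn1`: a limit only, > 100 ug/mL

Compound 3 therefore stands at the limit of this assay, not at a number, and it shares that position with the other two, as the limit of > 100 ug/mL in this assay, at which 3 of the 3 values shown sit, records. Among the measured compounds shown here, the one comparable pair, a step that the two limits leave unreadable from compound 1 to compound 2, is a step between two limits and gives no readable size.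

Compound 4, `CCCCCCCCCCn1cc(-c2nc3ccccc3cc2CCCCC)nn1`, differs from compound 3 by decyl in place of 4-fluorophenyl on an aromatic nitrogen. For the measured compounds named here, no measured step covers this exchange. What the numbers do show is that compound 1 and compound 2, which both carry decyl on the aromatic nitrogen, also sit at the limit, so nothing points to a value inside the readable range for compound 4 in this assay.

The expectation is that compound 4 also returns only a limit, giving an estimated 150 ug/mL with a range from 60 ug/mL to 400 ug/mL, and an expected step that the limit leaves unreadable from compound 3 to compound 4 of no readable size, the result awaited being a measurement in this assay.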

Compound 4, half-maximal inhibitory concentration: > 100 ug/mL
Compound 4: a limit, no number; the forecaster's own chance of this, stated with the estimate: 85%; the middle value is on the limit's open side.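

Among the compounds shown here, no step to compound 4 from compound 1, compound 2 or compound 3 can be read, since compound 4 also gives only a limit in this assay: the limit of > 100 ug/mL in this assay, at which 4 of the 4 values shown sit.

The compounds shown leave open whether any change of chain or of the group on the aromatic nitrogen brings a value inside the readable range of this assay.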